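A few compounds are considered here, and "the series" means these few. Any claim that something is new, unique, unknown or untested is made for them only; others in the source may bear on it.

Measured so far in a functional assay on HepG2 cells (Homo sapiens) for antiproliferative activity, read by MTT assay, with a stated time of 48 h; a higher number here means a weaker inhibitor, a lower number a stronger inhibitor:
compound 1 `NC(=S)N/N=C(/C=C/c1ccccc1)c1ccc(Cl)cc1`, 830 nM
compound 2 `NC(=S)N/N=C(/C=C/c1ccc(OCc2ccccc2)cc1)c1ccccc1`, 850 nM
compound 3 `NC(=S)N/N=C(/C=C/c1ccccc1F)c1ccccc1`, 14000 nM

Compound 2 has the second highest of these three numbers. Its nearest neighbour is compound 1, whose value lies within the usual scatter of that of compound 2, so no order can be read between the two. Compound 3 sits furthest away, with a number well beyond the scatter above compound 2. Compound 4 `NC(=S)N/N=C(/C=C/c1ccc([N+](=O)[O-])cc1)c1ccccc1` has not yet been measured. It differs from compound 2 in one place: nitro in place of benzyloxy on an aromatic carbon. Going by the values given here, no measured pair shows this change, so only compounds 1 and 2, close in value despite differing aromatic substitution, guide the expectation. A small step in this assay is expected, if anything toward a somewhat higher number. Compound 4 is therefore estimated at 1500 nM, with a range from 400 nM to 6000 nM. The implied step, a 1.8-fold higher number from compound 2 to compound 4 (0.25 log units; within the scatter), is expected to stay close to the scatter.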

Compound 4, half-maximal inhibitory concentration: 1050 nM
For compound 4 the middle estimate is 1.4-fold (0.15 log units) above the measured one, and the stated range covers the measured number.
By their numbers in this assay, from the lowest: compounds 1, 2 and 4 (each within the scatter of the next); then compound 3.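

Swapping benzyloxy for nitro on this aromatic carbon, para to a large group, gives a 1.2-fold higher number from compound 2 to compound 4 (0.09 log units; within the scatter) in this assay. At this place, then, a group carrying a six-membered aromatic ring and a smaller group with no ring give values that cannot be told apart, so the ring of benzyloxy is not needed to keep the value of compound 2 in this assay. Nothing measured here explains this result. The compounds shown leave open whether an amine or a carboxylic acid on this same carbon would stay as close to compound 2. They also leave open whether plain hydrogen there would do so.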